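Changing the amide substituent on a dilauroyl lipopeptide core

The source may report more compounds than this note shows. Statements on the series, on what has been measured and on what is new or still open speak of the compounds shown alone.

Measured compounds:
compound 1 `CCCCCCCCCCCC(=O)OC[C@H](CSC[C@@H](N)C(=O)NC(C)(C)CO)OC(=O)CCCCCCCCCCC` – 15500 nM
compound 2 `CCCCCCCCCCCC(=O)OC[C@H](CSC[C@@H](N)C(=O)NC(CC)COC)OC(=O)CCCCCCCCCCC` – 71.8 nM
compound 3 `CCCCCCCCCCCC(=O)OC[C@H](CSC[C@@H](N)C(=O)NCCCCCCCCCC(=O)O)OC(=O)CCCCCCCCCCC` – 4400 nM

In an assay on HEK293 cells for agonist activity at Toll-like receptor 2 (Homo sapiens) (a lower number here means that less compound is needed, a higher number that more compound is needed for the effect), compound 3 stands second highest of the three values, nearer to compound 1 than to compound 2. Compound 4 `CCCCCCCCCCCC(=O)OC[C@H](CSC[C@@H](N)C(=O)NCCN)OC(=O)CCCCCCCCCCC` is compound 3 with amino in place of 7-carboxyheptyl on a saturated chain carbon, two bonds along the chain from an amide-type nitrogen. Within the data shown here, two measured steps concern the same amide nitrogen: a 3.5-fold lower number from compound 1 to compound 3 (0.55 log units; beyond the scatter) and a 61-fold higher number from compound 2 to compound 3 (1.79 log units; beyond the scatter). Both show that the substituent on this nitrogen moves the value strongly, yet neither matches a short amino-bearing chain, so the direction is uncertain. A step of moderate size is therefore expected, a 2.9-fold lower number from compound 3 to compound 4 (0.47 log units; beyond the scatter), with a wide range. Compound 4 is estimated at 1500 nM, between 150 nM and 15000 nM.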

Compound 4, half-maximal effective concentration: 5240 nM
Beside the measured number, compound 4's estimate is 3.5-fold (0.54 log units) below it; the range from low to high includes it.
By their numbers in this assay, from the lowest: compound 2; then compounds 3 and 4 (each within the scatter of the next); then compound 1.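

In this assay, replacing the 9-carboxynonyl chain on the amide-type nitrogen with the far shorter 2-aminoethyl chain leaves the two compounds indistinguishable (a 1.2-fold higher number from compound 3 to compound 4 (0.08 log units; within the scatter)). A chain ending in a carboxylic acid and one ending in an amine can therefore give matching values here. The 2-aminoethyl chain still stands well apart from 1-(methoxymethyl)propyl (a 73-fold higher number from compound 2 to compound 4 (1.86 log units; beyond the scatter)) and more modestly from 1-(hydroxymethyl)-1-methylethyl (a 3.0-fold lower number from compound 1 to compound 4 (0.47 log units; beyond the scatter)).

As far as these compounds go, how a 2-carboxyethyl or 9-aminononyl chain would compare remains open, since chain length and end group change together here. No supporting data explain these values.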